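Substituent swaps at one aromatic carbon and acid dissociation

The compounds below may be only part of what the source reports. "The series", "measured", "known", "first", "only" and "open" are said of these compounds alone.

Values in a physicochemical assay for acid dissociation:
compound 1, `COc1cccc(CNCCCNc2ccnc3cc(-c4ccc(F)cc4)ccc23)c1O`: 9.47
compound 2, `COc1cccc(CNCCCNc2ccnc3cc(CC4CCCCC4)ccc23)c1O`: 9.47
compound 3, `COc1cccc(CNCCCNc2ccnc3cc(CC(C)C)ccc23)c1O`: 9.47

Compound 3 stands level with compounds 1 and 2 at the digits shown. The three steps between the measured compounds, no change at the digits printed from compound 1 to compound 2 (within the scatter), no change at the digits printed from compound 1 to compound 3 (within the scatter) and no change at the digits printed from compound 2 to compound 3 (within the scatter), all sit within the scatter, even though the group on the aromatic carbon of the shared core changes from an aryl to a cycloalkylmethyl to a short branched alkyl.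

Compound 4, `COc1ccccc1Oc1ccc2c(NCCCNCc3cccc(OC)c3O)ccnc2c1`, differs from compound 3 as follows: 2-methoxyphenoxy in place of isobutyl on an aromatic carbon. The change sits on the same aromatic carbon of the shared core that was varied in every measured step, and none of those steps moved the value in this assay beyond the scatter. The incoming group brings two hydrogen-bond acceptors, whereas the earlier groups brought none, so the measured steps cover this change only in part. Still, the expectation is a step of no change at the digits printed from compound 3 to compound 4 (within the scatter), that is none beyond the scatter. Compound 4 is expected to give 9.47, within 9.1 to 9.8.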

Compound 4, acid dissociation constant: 9.28
Estimate against measurement, compound 4: 0.19 log units above; the measured number falls inside the stated range.
By their numbers in this assay, from the lowest: compounds 4, 1, 2 and 3 (each within the scatter of the next).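

Working notes: in this assay, 2-methoxyphenoxy on this aromatic carbon gives a number 0.19 log units lower from compound 3 to compound 4 (within the scatter) and the comparisons with the other two groups give a number 0.19 log units lower from compound 2 to compound 4 (within the scatter) and a number 0.19 log units lower from compound 1 to compound 4 (within the scatter). The position therefore now covers an incoming group with an oxygen attached directly to the aromatic carbon and with hydrogen-bond acceptors, and all three steps stay within the scatter, so no order among the four compounds can be drawn even though the printed digits are no longer identical. Nothing available bears on why the digits of compound 4 differ from the others.

As far as these compounds go, whether an amine or a carboxylic acid on this same aromatic carbon would also stay within the scatter in this assay remains open. These compounds also leave open which proton the number reports, since every change shown sits at this one position.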